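Replacing Dimethylamino with a Dimethylaminopropylsulfanyl Chain

The compounds below may be only part of what the source reports. "The series", "measured", "known", "first", "only" and "open" are said of these compounds alone.

Two measured compounds share a common core and differ in the aromatic group attached to it. Compound 1 `COc1ccc(Nc2nccc(-c3sc(N(C)C)nc3C)n2)c(OC)c1` carries a small amine-bearing ring, and in an assay for inhibition of MAP kinase-interacting serine/threonine-protein kinase 2 (Homo sapiens), read by TR-FRET (a lower number here means a stronger inhibitor, a higher number a weaker inhibitor), compound 1 gives 200 nM. Compound 2 `COc1ccc(Nc2nccc(-c3cn(C(C)C)c4ccccc34)n2)c(OC)c1` carries a different aromatic group, and in this assay compound 2 gives 220 nM. The two numbers lie within the scatter of one another, so neither compound can be placed above the other.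

Compound 3 `COc1ccc(Nc2nccc(-c3sc(SCCCN(C)C)nc3C)n2)c(OC)c1` has not yet been measured. It differs from compound 1 in a single place: (3-(dimethylamino)propyl)sulfanyl in place of dimethylamino on an aromatic carbon. The change sits on an aromatic carbon of a five-membered aromatic ring with one nitrogen and one sulfur. Within the data shown here, no step between measured compounds shows how this assay responds to a change at this place, and compound 1 and compound 2 differ in more than one place, so they give no direct guide.

Given this, only a modest step is expected, if any beyond the scatter, with a slight lean toward a higher number. Compound 3 is expected to give 300 nM, within a range from 100 nM to 900 nM. The step of a 1.5-fold higher number from compound 1 to compound 3 (0.18 log units; within the scatter) is thus expected to be small.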

Compound 3, inhibition constant: 1150 nM
Compound 3: the middle estimate sits 3.8-fold (0.58 log units) below what was measured; the measured number lies above the stated range.
By their numbers in this assay, from the lowest: compounds 1 and 2 (each within the scatter of the next); then compound 3.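

This position, on an aromatic carbon next to the ring nitrogen and next to the ring sulfur, now has its first reading in this assay: (3-(dimethylamino)propyl)sulfanyl in place of dimethylamino gives a 5.8-fold higher number from compound 1 to compound 3 (0.76 log units; beyond the scatter). The dimethylamino group is still present in compound 3, but at the end of the longer sulfur-linked chain, so its presence alone does not preserve the number seen for compound 1. No measurement at hand bears on what lies behind this step.

This one step changes the sulfur link and the chain length together, so it cannot separate them; a methylsulfanyl group, or a propyl chain ending in dimethylamino and joined through oxygen or through an amine nitrogen, would be needed to tell them apart. The compounds shown also leave open whether a shorter ethyl chain, or a propyl chain ending in a morpholine or a carboxylic acid, would stay close to compound 1 or move as far from it as compound 3.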